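Aryl substituent change from compound 3 to compound 4

The source may hold more compounds than are shown below. What is called first, only, known or untested is meant among the compounds shown, and "the series" means these compounds.

compound 1 `CCn1c(-c2ccccc2)cc2onc(-c3ccccc3)c2c1=O`: 910 nM
compound 2 `Cn1c(-c2ccc(F)cc2)cc2onc(-c3ccccc3)c2c1=O`: 72 nM
compound 3 `CN(C)c1ccc(-c2cc3onc(-c4ccccc4)c3c(=O)n2C)cc1`: 140 nM

In a functional assay on CHO cells for antagonist activity at metabotropic glutamate receptor 7 (Rattus norvegicus), read by FLIPR and calcium flux (on this read-out higher numbers stand for weaker inhibition and lower numbers for stronger inhibition), compound 3 stands second highest of the three numbers; its nearest neighbour is compound 2, within the scatter, and its furthest is compound 1, beyond the scatter and with the higher number. Compound 4 `CCCc1ccc(-c2cc3onc(-c4ccccc4)c3c(=O)n2C)cc1` differs from compound 3 by propyl in place of dimethylamino on an aromatic carbon. Among the measured compounds shown here, the only measured step at this position is a 1.9-fold higher number from compound 2 to compound 3 (0.29 log units; within the scatter), which stayed within the scatter; no measured step involves propyl, so nothing points to a large move in either direction. The step is therefore expected to be a 1.2-fold lower number from compound 3 to compound 4 (0.07 log units; within the scatter), not beyond the scatter. Compound 4 is estimated at 120 nM, with a range from 40 nM to 400 nM.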

Compound 4, half-maximal inhibitory concentration: 150 nM
For compound 4 the middle estimate is 1.3-fold (0.10 log units) below the measured one, and the stated range covers the measured number.
By their numbers in this assay, from the lowest: compounds 2, 3 and 4 (each within the scatter of the next, the first and the last beyond it); then compound 1.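

In this assay, propyl in place of dimethylamino gives a 1.1-fold higher number from compound 3 to compound 4 (0.03 log units; within the scatter) and so does not separate the group with one hydrogen-bond acceptor from the all-carbon group at this aromatic carbon. Propyl in place of fluoro gives a 2.1-fold higher number from compound 2 to compound 4 (0.32 log units; beyond the scatter) as a modest step, the only one at this position that lies beyond the scatter. No available evidence bears on the reason for either step. Still open, going by these compounds, is how a carboxylic acid, a primary amine or a longer chain at this carbon would compare with propyl.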